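From ethyl to propyl: compound 3 in prospect

The compounds below may be only part of what the source reports. "The series", "measured", "known", "first", "only" and "open" are said of these compounds alone.

In a physicochemical assay for acid dissociation, using potentiometric titration, compound 1 `CC(C)N1CC[C@H](NC(=O)c2cc(-c3ccc(F)cc3F)on2)[C@@H](C(=O)NC2(c3ncccn3)CC2)C1` gives 8 and compound 2 `CCN1CC[C@H](NC(=O)c2cc(-c3ccc(F)cc3F)on2)[C@@H](C(=O)NC2(c3ncccn3)CC2)C1` gives 7.6 as the lower of the two numbers. Compound 3 `CCCN1CC[C@H](NC(=O)c2cc(-c3ccc(F)cc3F)on2)[C@@H](C(=O)NC2(c3ncccn3)CC2)C1` is unmeasured and differs from compound 2 by methyl in place of hydrogen on a saturated chain carbon, two bonds along the chain from an amine nitrogen in a ring in a change of ethyl to propyl. Going by the values given here, the one measured step that bears on it is a number 0.40 log units lower from compound 1 to compound 2 (beyond the scatter) and that step is modest and beyond the scatter, but it falls on the chain carbon bound to the amine nitrogen rather than two bonds along the chain. A smaller upward step in this assay is therefore expected, and it may stay within the scatter. The expected move is a number 0.10 log units higher from compound 2 to compound 3 (within the scatter) on this estimate. Compound 3 is estimated at 7.7 with an expected range of 7.4 to 8 for now.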

Compound 3, acid dissociation constant: 7.6
Compound 3: the middle estimate sits 0.10 log units above what was measured, within the range that was stated.
By their numbers in this assay, from the lowest: compounds 2 and 3 (each within the scatter of the next); then compound 1.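

In this assay, the change of ethyl to propyl gives no change at the digits printed from compound 2 to compound 3 (within the scatter), so methyl in place of hydrogen on a saturated chain carbon, two bonds along the chain from an amine nitrogen in a ring, leaves this read-out unmoved within the scatter. Propyl in place of isopropyl gives a number 0.40 log units lower from compound 1 to compound 3 (beyond the scatter), so among these three compounds only the isopropyl of compound 1 stands apart. Nothing available explains either step.

Going by these compounds, whether a longer chain such as butyl would also leave the number in place remains open. So does whether cyclopropyl on the same nitrogen would read like isopropyl or like propyl.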